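Trading a 2-Methoxybenzyl for a Propyl Chain

A few compounds are considered here, and "the series" means these few. Any claim that something is new, unique, unknown or untested is made for them only; others in the source may bear on it.

Of the compounds shown here, three that share one core have been tested in a functional assay on cells (Platelet, Homo sapiens) for inhibition; a lower number here means a stronger inhibitor, a higher number a weaker inhibitor. Compound 1 `CCOC(=O)c1cccc(-c2n[nH]c3ccccc23)c1` reaches only the limit of the assay, giving > 10000 nM. Compound 2 `CCOC(=O)c1ccc(-c2nn(C)c3ccccc23)cc1` likewise gives only a limit, > 10000 nM. Compound 3 `CCOC(=O)c1ccc(-c2nn(Cc3ccccc3OC)c3ccccc23)cc1` also gives only a limit, > 10000 nM. Among the measured compounds shown here, the one step that alters the same place, a step that the two limits leave unreadable from compound 2 to compound 3, is therefore unreadable, since both of its ends are limits. Compound 3 thus stands at the limit together with the other two, as the evidence the limit of > 10000 nM in this assay, at which 3 of the 3 values shown sit, shows.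

Compound 4 `CCCn1nc(-c2ccc(C(=O)OCC)cc2)c2ccccc21` differs from compound 3 in one place: ethyl in place of 2-methoxyphenyl on a saturated chain carbon bound to an aromatic nitrogen. For the measured compounds named here, no measured step shows what this change does, because the only comparable step, a step that the two limits leave unreadable from compound 2 to compound 3, has no readable size. Going by the values given here, with every value so far sitting at the limit, the most reasonable expectation is that compound 4 stays there as well, so the estimated step that the limit leaves unreadable from compound 3 to compound 4 is expected to be about nil. Compound 4 is therefore estimated to give around 20000 nM, within a range from 5000 nM to 100000 nM, most probably reported again only as a limit.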

Compound 4, half-maximal inhibitory concentration: > 10000 nM
Compound 4 gave a limit, no number; the forecaster's own chance of this, stated with the estimate: 85%; the middle value lies beyond the limit too.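

Compound 4 gives > 10000 nM, which is again a limit and not a number. The steps from compound 2 and from compound 3 to compound 4 therefore cannot be read: the limit of > 10000 nM in this assay, at which 4 of the 4 values shown sit.

The compounds shown leave open how strongly any of them inhibits, and which change to the shared core would yield a measurable number.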